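The source may hold more compounds than are shown below. What is called first, only, known or untested is meant among the compounds shown, and "the series" means these compounds.

Within the data shown here, compound 2 `COc1ccc(C(=O)/C=C/c2cc(-c3cc(OC)c(OC)c(OC)c3)n[nH]2)cc1OC` is the only compound in this set that gives a number: in a functional assay on NCI-H460 cells (Homo sapiens) for inhibition, read by sulforhodamine B assay, with a stated time of 48 h (on this read-out lower numbers stand for higher toxicity in this test and higher numbers for lower toxicity in this test), compound 2 gives 7860 nM. Compound 1 `COc1cc(-c2cc(/C=C/C(=O)c3ccc(Cl)c(Cl)c3)[nH]n2)cc(OC)c1OC` reaches only a limit of the test; in this assay compound 1 gives > 100000 nM, which is the limit of > 100000 nM in this assay, at which 1 of the 2 values shown sits. Among the measured compounds shown here, the single measured step, an at least 12-fold lower number from compound 1 to compound 2 (1.10 log units; beyond the scatter), concerns the ring on the carbonyl carbon. Compound 3 `COc1ccc(C(=O)/C=C/c2cc(-c3cc(OC)c(OC)c(OC)c3)n[nH]2)cc1` differs from compound 2 by hydrogen in place of methoxy on an aromatic carbon. That change also sits on the ring attached to the carbonyl carbon, but the measured step swapped one whole substituent pattern for another and removes no single methoxy, so it bears only loosely on the new change. No step within the scatter is shown to anchor a small change either. Compound 3 is therefore expected to move only modestly and in the direction of a higher number, a 1.5-fold higher number from compound 2 to compound 3 (0.18 log units; within the scatter), with an estimated value of 12000 nM and a range from 3500 nM to 45000 nM.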

Compound 3, concentration lethal to 50% of the cells: 8180 nM
For compound 3 the middle estimate is 1.5-fold (0.17 log units) above the measured one; measured number inside the range.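

Hydrogen in place of methoxy, on an aromatic carbon ortho to a methoxy group, gives a 1.0-fold higher number from compound 2 to compound 3 (0.02 log units; within the scatter) in this assay, so at this position the methoxy group makes no difference that this test can detect. With 4-methoxyphenyl in place of 3,4-dichlorophenyl, the shift remains an at least 12-fold lower number from compound 1 to compound 3 (1.08 log units; beyond the scatter), so the large difference from compound 1 does not depend on the methoxy group that compound 3 lacks. Compound 1 stands only at a limit of the test: the limit of > 100000 nM in this assay, at which 1 of the 3 values shown sits.

The compounds shown leave open whether the remaining methoxy group of the 4-methoxyphenyl ring matters, and what a hydroxyl group, an amine or a fluorine atom would do in its place. As far as these compounds go, how far compound 1 truly lies from compound 2 and compound 3 also stays open.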